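Chloro for hydrogen on two amide-linked cores

A few compounds are considered here, and "the series" means these few. Any claim that something is new, unique, unknown or untested is made for them only; others in the source may bear on it.

Compound 1 `O=C(CCCCC1CCSS1)Nc1ccccn1` gives 39.3% in a functional assay on NCI-H460 cells (Homo sapiens) for inhibition, read by MTT assay, with a stated time of 24 h, tested at 100 ug/mL; on this read-out higher numbers stand for more inhibition of growth at the one concentration tested and lower numbers for less inhibition of growth. Compound 2 `O=C(CCCCC1CCSS1)Nc1ccc(Cl)cn1` gives 58.6% in this assay. Compound 3 `O=C(CCCCC(CCSC(=O)c1ccccc1)SC(=O)c1ccccc1)Nc1ccccc1` is reported in this assay as "not active" (no number reported).

The step of a number 19.3 percentage points higher from compound 1 to compound 2 (beyond the scatter) came from chloro in place of hydrogen on an aromatic carbon. Compound 4 `O=C(CCCCC(CCSC(=O)c1ccccc1)SC(=O)c1ccccc1)Nc1ccccc1Cl` carries the same kind of change, (chloro in place of hydrogen on an aromatic carbon), but on the core of compound 3; how that core differs from the core of compound 1 is not broken down here, and the place also differs, being on a ring of carbon only and ortho to a large group rather than on a ring with one nitrogen, para to a large group. Since compound 3 is only reported as not active, the earlier step is a weak guide, and a smaller rise is expected. Compound 4 is estimated at 15%, between 0% and 40%.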

Compound 4, percent growth inhibition at one concentration: "not active" (no number reported)
Compound 4: no number reported; no gap can be computed for the estimate.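

Compound 3 gives "not active" (no number reported) and compound 4 gives "not active" (no number reported) in this assay, so no step can be read between them. The compounds shown leave open whether 2-chlorophenyl for phenyl changes growth inhibition on this core. No measurement shown offers an explanation.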